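Swapping Benzylamino for Furan-2-yl at a Solubility Limit

The compounds below may be only part of what the source reports. "The series", "measured", "known", "first", "only" and "open" are said of these compounds alone.

In a physicochemical assay for solubility, at pH 7 (on this read-out lower numbers stand for lower solubility and higher numbers for higher solubility), compound 1 `CC(C)(C)C(=O)N1Cc2c(NC(=O)C3CCNCC3)n[nH]c2C1(C)C` gives > 225000 nM, which is a limit and not a number. Compound 2 `CN1CCC(C(=O)N2Cc3c(NC(=O)NCc4ccccc4)n[nH]c3C2(C)C)CC1` gives > 225000 nM, again only a limit. Compound 2 therefore stands at the limit of > 225000 nM in this assay, at which 2 of the 3 values shown sit. Compound 3 `CC(=O)N1CCC(C(=O)N2Cc3c(NC(=O)c4ccc(F)cc4)n[nH]c3C2(C)C)CC1` gives an actual number, 204000 nM. Compound 4 `CN1CCC(C(=O)N2Cc3c(NC(=O)c4ccco4)n[nH]c3C2(C)C)CC1` carries furan-2-yl in place of benzylamino on a carbonyl carbon. For the measured compounds named here, no measured pair shows this change, so only a small downward move, not clearly beyond the scatter, is expected, and the estimated change is an at least 1.0-fold lower number from compound 2 to compound 4 (0.02 log units; that floor lies within the scatter). The expected reading for compound 4 in this assay is 210000 nM, with an estimated range of 120000 nM to 350000 nM.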

Compound 4, solubility: > 225000 nM
Compound 4 was reported as a limit; the forecaster's own chance of this, stated with the estimate: 60%; middle value at least 1.0-fold (0.02 log units) away from the limit.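

For the compounds shown here, compound 2 and compound 4 are both reported only as limits, so no step between them can be read: the limit of > 225000 nM in this assay, at which 3 of the 4 values shown sit.

Going by these compounds, the actual values of compound 2 and compound 4, and so how furan-2-yl compares with benzylamino on a carbonyl carbon, remain open.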